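Phenyl in place of the amide hydrogen, compound 3

The source may hold more compounds than are shown below. What is called first, only, known or untested is meant among the compounds shown, and "the series" means these compounds.

Compound 1 `Cn1cc(C2=C(c3nn(CCCn4cncn4)c4ncccc34)C(=O)N(c3ccccc3)C2=O)c2ccccc21` gives > 100000 nM (a limit)
Compound 2 `Cn1cc(C2=C(c3nn(CCCCn4ccnc4)c4ncccc34)C(=O)NC2=O)c2ccccc21` gives 31800 nM

For the measured compounds named here, in a functional assay on K562 cells (Homo sapiens) for antiproliferative activity, read by MTT assay, with a stated time of 48 h (a lower number here means a stronger inhibitor, a higher number a weaker inhibitor), compound 2 gives 31800 nM as the only true number so far. Compound 1 gives > 100000 nM as a limit of the assay and not a number.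

Compound 3 `Cn1cc(C2=C(c3nn(CCCCn4ccnc4)c4ncccc34)C(=O)N(c3ccccc3)C2=O)c2ccccc21` differs from compound 2 by phenyl in place of hydrogen on an amide-type nitrogen in a ring. Going by the values given here, no measured step isolates this change. Compound 1 bears the same phenyl on that nitrogen with a different side chain and stands at > 100000 nM as a limit, so a shift towards weaker inhibition in this assay is expected. Its size is expected to lie near the edge of the usual scatter, with little evidence to go on. The expected step is a 2.0-fold higher number from compound 2 to compound 3 (0.31 log units; beyond the scatter) in that direction. For compound 3 the estimated value is 65000 nM with a range from 20000 nM to 150000 nM and a report of a limit alone remains possible.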

Compound 3, half-maximal inhibitory concentration: 5030 nM
Beside the measured number, compound 3's estimate is 13-fold (1.11 log units) above it; measured number below the stated range.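

In this assay, phenyl in place of hydrogen on the amide-type nitrogen in a ring gives a 6.3-fold lower number from compound 2 to compound 3 (0.80 log units; beyond the scatter), so this position accepts an aromatic ring and the amide hydrogen is not required for the activity seen in this pair. The phenyl does not secure that activity alone: with the same phenyl held on the nitrogen, (1H-imidazol-1-yl)methyl in place of 1H-1,2,4-triazol-1-yl on a saturated chain carbon gives an at least 19-fold lower number from compound 1 to compound 3 (1.29 log units; beyond the scatter), which ties the result at this nitrogen to the side chain it is paired with. Compound 1 stands at a limit of the assay and not at a number, so that second step gives only a bound: the limit of > 100000 nM in this assay, at which 1 of the 3 values shown sits.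

Still open, as far as these compounds go, is whether a methyl, a benzyl or a 4-methoxyphenyl group on the same nitrogen would follow the shift seen with phenyl, or whether the ring itself is what counts. Also open, from the compounds shown here alone, is how a compound with the amide hydrogen and the 1H-1,2,4-triazol-1-yl end would read, and whether a pentyl chain carrying the imidazole would hold the number of compound 3.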